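A Halogen Swap on a Weakly Cytotoxic Diketopiperazine-like Scaffold

The source may hold more compounds than are shown below. What is called first, only, known or untested is meant among the compounds shown, and "the series" means these compounds.

Of the compounds shown here, three that share one core have been tested in a functional assay on NCI-H1975 cells (Homo sapiens) for cytotoxicity, read by CCK-8 assay, with a stated time of 72 h; a higher number here means a weaker inhibitor, a lower number a stronger inhibitor. Compound 1 `COc1ccccc1/C=c1/[nH]c(=O)/c(=C\c2cccc(Cl)c2Cl)[nH]c1=O` gave no number and was reported as "not active" (no number reported). Compound 3 `C=CCn1c(=O)/c(=C\c2cccc(Br)c2)[nH]c(=O)/c1=C\c1cccc(Br)c1` was likewise reported as "not active" (no number reported). Compound 2 `C=CCn1c(=O)/c(=C\c2cccc(Cl)c2Cl)[nH]c(=O)/c1=C\c1ccccc1OC` is the only one of the three with a measured value: in this assay compound 2 gives 4500 nM. Among the compounds with values here, it therefore stands alone as the sole compound with a quantified result; nothing in the other two entries allows a comparison of size or direction with it.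

The next compound, compound 4 `C=CCn1c(=O)/c(=C\c2ccccc2F)[nH]c(=O)/c1=C\c1ccccc1OC`, differs from compound 2 in a single place: 2-fluorophenyl in place of 2,3-dichlorophenyl on a double-bonded chain carbon bound to an aromatic carbon. Within the data shown here, no measured pair in this set shows what such a change does, so the expectation can rest only on the fact that compound 2 already sits at a weak level in this assay and that the two companions without a number were reported as not active.

The step from compound 2 to compound 4 is expected to be a 2.0-fold higher number from compound 2 to compound 4 (0.30 log units; within the scatter), leaning toward weaker inhibition, though it could fall within ordinary scatter. Compound 4 is estimated to give 9000 nM in this assay, with an expected range from 3000 nM to 40000 nM.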

Compound 4, half-maximal inhibitory concentration: 25100 nM
Estimate against measurement, compound 4: 2.8-fold (0.45 log units) below, and the stated range covers the measured number.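

In this assay the replacement of 2,3-dichlorophenyl by 2-fluorophenyl, on a double-bonded chain carbon bound to an aromatic carbon, gives a 5.6-fold higher number from compound 2 to compound 4 (0.75 log units; beyond the scatter), a modest step toward weaker inhibition. Within the data shown here, this is the first direct sign that the group at this place affects the read-out, since the earlier compounds offered a single number and no pair that could be compared. Why the number rises stays unexplained, as no measurement here bears on the cause.

The step also changes two things at once, taking away both chlorine atoms and bringing in one fluorine atom, so the compounds shown cannot separate the effect of losing chlorine from that of adding fluorine. They also leave open how this place would respond to a plain phenyl ring, a 2-chlorophenyl group, or a phenyl ring carrying an amine or a carboxylic acid in place of a halogen.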